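Cyano for Hydroxy on a Bridged Tricyclic Core

A few compounds are considered here, and "the series" means these few. Any claim that something is new, unique, unknown or untested is made for them only; others in the source may bear on it.

Compound 1 `OC12CCCC3CC(CCC31)C2` gives 6000000 nM in an ADME assay (Gallus gallus) for cytotoxicity, read by microscopy, with a stated time of 24 h; a higher number here means that more compound is tolerated, a lower number that less compound is tolerated.
Compound 2 `O=C1C2CCC3C(CCCC13)C2` gives 2400000 nM in this assay.
Compound 3 `O[C@@H]1C2CCCC3C[C@@H]1CC[C@@H]32` gives 750000 nM in this assay.

Among these three numbers compound 1 stands highest. Compound 2, with its ketone on the shared core, is the nearest to it, and that gap already lies beyond the usual scatter; compound 3, the secondary alcohol, is the furthest, and that gap lies well beyond it. Going by the values given here, no two of the measured compounds differ in a single place, so no counted step between them is available.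

Compound 4 `N#CC12CCCC3CC(CCC31)C2` has not yet been measured. It differs from compound 1 in one place: cyano in place of hydroxy on a saturated ring carbon. Among the compounds with values here, nothing among the measured compounds shows what replacing the hydroxy by a cyano does to the tolerated concentration, so the direction of the step must rest on compound 1 alone. He expects the change to lower the number only modestly, with the step from compound 1 to compound 4 estimated as a 2.0-fold lower number from compound 1 to compound 4 (0.30 log units; within the scatter), at the edge of the scatter rather than clearly beyond it. Compound 4 is therefore estimated at 3000000 nM in this assay, within a range from 1000000 nM to 8000000 nM.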

Compound 4, minimum cytotoxic concentration: 850000 nM
Compound 4: middle estimate off by 3.5-fold (0.55 log units), on the high side; the measured number lies below the stated range.
By their numbers in this assay, from the lowest: compounds 3 and 4 (each within the scatter of the next); then compound 2; then compound 1.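

Going by these compounds alone, at this saturated ring carbon, the exchange of hydroxy for cyano is not a neutral one in this assay: it gives a 7.1-fold lower number from compound 1 to compound 4 (0.85 log units; beyond the scatter), the first counted step, and it shows that the number responds to what this position carries. The change alters several things at once, since hydroxy, with 1 heavy atom and 1 hydrogen-bond donor, gives way to cyano, with 2 heavy atoms, 0 hydrogen-bond donors and a triple bond, while 1 hydrogen-bond acceptor is present on each side, and a single step cannot separate these differences. No measurement is at hand that accounts for the lower number.

The compounds shown leave open whether the step follows from losing hydroxy or from bringing in cyano, and whether an amine, a methyl group or a carboxylic acid on the same saturated ring carbon would stay close to compound 1 or fall as compound 4 does. They also leave open whether the same exchange would give a step of similar size elsewhere on the shared core.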